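The source may hold more compounds than are shown below. What is called first, only, known or untested is meant among the compounds shown, and "the series" means these compounds.

In an assay on isolated protein for inhibition of serine/threonine-protein kinase D2 (Homo sapiens), read by mobility shift assay, tested at 30 uM (on this read-out lower numbers stand for less inhibition and higher numbers for more inhibition at the one concentration tested (going by the name of the read-out)), compound 1 `COc1cccc(-c2cc3[nH]nc(N)c3c(=O)[nH]2)c1` gives 17%. Compound 2 `Cn1nc(N)c2c(=O)[nH]c(-c3ccccc3)cc21` gives 14% in this assay; of the two numbers recorded it holds the smaller, yet its gap to compound 1 lies within the scatter, so the two cannot be told apart. Compound 3 `COc1cccc(-c2cc3c(c(N)nn3C)c(=O)[nH]2)c1` differs from compound 2 by methoxy in place of hydrogen on an aromatic carbon. Since no change between two measured compounds in a single place is available, the step of a number 2 percentage points higher from compound 2 to compound 3 (within the scatter) is expected to stay within the scatter, as compound 1 already carries the same methoxy and gives 17%. Compound 3 is therefore estimated at 16% in this assay, between 4% and 30%.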

Compound 3, a percentage reported as inhibition, at one concentration (the size of the read-out at that concentration, not a potency): 25%
The estimate for compound 3 lay 9 percentage points below the measured number, within the range that was stated.
By their numbers in this assay, from the lowest: compounds 2, 1 and 3 (each within the scatter of the next, the first and the last beyond it).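

In this assay, for the compounds shown here, methoxy in place of hydrogen on an aromatic carbon, meta to a large group, gives a number 11 percentage points higher from compound 2 to compound 3 (beyond the scatter), the first single change here to exceed the scatter. Methyl in place of hydrogen on an aromatic nitrogen, by contrast, gives a number 8 percentage points higher from compound 1 to compound 3 (within the scatter), so that change cannot be told from none. Nothing available bears on why the methoxy step arises. The compounds shown leave open whether a hydroxyl, an amine or a longer ether chain at this place would give a similar step, and whether methoxy elsewhere on this ring would.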